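Bis(4-methoxyphenyl) dichloroacetanilide: expected cytotoxicity

A few compounds are considered here, and "the series" means these few. Any claim that something is new, unique, unknown or untested is made for them only; others in the source may bear on it.

Measured so far in a functional assay on A549 cells (Homo sapiens) for cytotoxicity, read by MTT assay, with a stated time of 68 h; on this read-out higher numbers stand for weaker inhibition and lower numbers for stronger inhibition:
- compound 1 `O=C(Nc1cccc(-c2ccc(F)cc2)c1)C(Cl)Cl`, compound 1 gives 7840 nM
- compound 3 `COc1ccc(-c2cccc(NC(=O)C(Cl)Cl)c2)cc1`, compound 3 gives 8530 nM
- compound 2 `O=C(Nc1cccc(-c2ccc(-c3ccccc3)cc2)c1)C(Cl)Cl`; for compound 2 this assay reports only a limit, > 50000 nM, not a number

Compound 3 holds the highest of the two numbers shown, with compound 1 nearest at a 1.1-fold higher number from compound 1 to compound 3 (0.04 log units; within the scatter), so the two are not distinguishable on this read-out.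

Compound 4 `COc1ccc(-c2cc(NC(=O)C(Cl)Cl)cc(-c3ccc(OC)cc3)c2)cc1` is not yet measured. It differs from compound 3 in one place: 4-methoxyphenyl in place of hydrogen on an aromatic carbon.

Two measured steps speak to an aryl group entering the shared core. Phenyl in place of fluoro gave an at least 6.3-fold higher number from compound 1 to compound 2 (0.80 log units; beyond the scatter), with compound 2 sitting at the limit of > 50000 nM in this assay, at which 1 of the 3 values shown sits. The reverse change, methoxy in place of phenyl, gave an at least 5.8-fold lower number from compound 2 to compound 3 (0.76 log units; beyond the scatter). Both steps are beyond the scatter and both say that a further aryl group on the core brings weaker inhibition. The change to compound 4 is of the same kind, so a step toward a higher number, beyond the scatter, is expected.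

Compound 4 is therefore estimated at 35000 nM in this assay, within 12000 nM to 100000 nM, which means an expected step of a 4.1-fold higher number from compound 3 to compound 4 (0.61 log units; beyond the scatter). There is a real chance that this assay returns only a limit for compound 4, as it did for compound 2.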

Compound 4, half-maximal inhibitory concentration: 20800 nM
Estimate against measurement, compound 4: 1.7-fold (0.23 log units) above, and the stated range covers the measured number.
By their numbers in this assay, from the lowest: compounds 1 and 3 (each within the scatter of the next); then compound 4. At a limit, above all of these: compound 2.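

Notes on the free aromatic carbon of the shared core, meta to the ((dichloromethyl)carbonyl)amino group and meta to the 4-methoxyphenyl group: the earlier steps only exchanged a substituent on the existing aryl group, so this is the first reading of a change at this carbon. In this assay, 4-methoxyphenyl in place of hydrogen here gives a 2.4-fold higher number from compound 3 to compound 4 (0.39 log units; beyond the scatter), so a second aryl group at this carbon moves the read-out towards weaker inhibition, but only by a modest step, and compound 4 still returns a number. Compound 2 remains the only compound in the series that returns a limit and not a number: the limit of > 50000 nM in this assay, at which 1 of the 4 values shown sits.

With only hydrogen and 4-methoxyphenyl shown at this carbon, it stays open whether the step follows from the aryl ring itself or from its methoxy group, which a plain phenyl or a 4-fluorophenyl group at the same carbon would separate. Also open, on these data alone, is how much smaller or differently built groups would read here, such as a methyl group, an amine or a carboxylic acid.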